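Efficacy notes on hydroxycarbamoyl cyclopropyl replacement

The source may hold more compounds than are shown below. What is called first, only, known or untested is meant among the compounds shown, and "the series" means these compounds.

Compound 2 `NC(=O)CCc1ccc(NCc2cccc(Oc3ccccc3)c2)cc1` is the parent for this step. For the measured compounds named here, in a functional assay on CHO cells for agonist activity at Free fatty acid receptor 1 (Homo sapiens), read by a luciferase reporter (on this read-out higher numbers stand for larger maximal responses and lower numbers for smaller maximal responses), compound 2 gives 68%, the lowest of the two numbers so far; compound 1 `O=C(O)c1ccc(NCc2cccc(Oc3ccccc3)c2)cc1` gives 86% in this assay. Going by the values given here, the only measured step, a number 18 percentage points lower from compound 1 to compound 2 (beyond the scatter), shows that exchanging carboxy for 2-carbamoylethyl cost a modest amount of maximal response. Compound 3 `O=C(NO)[C@H]1C[C@@H]1c1ccc(NCc2cccc(Oc3ccccc3)c2)cc1` carries the change (2-(hydroxycarbamoyl)cyclopropyl in place of 2-carbamoylethyl on an aromatic carbon), on an aromatic carbon of a six-membered aromatic ring of carbon only, para to a large group. Among the compounds with values here, no measured step covers this exact exchange; the single step that bears on it, from compound 1 to compound 2, moved by a modest margin, so a step of similar or smaller size is expected here, most likely upward, though a result within the scatter cannot be excluded. The expected step is a number 10 percentage points higher from compound 2 to compound 3 (within the scatter). Compound 3 is therefore estimated at 78%, with a range of 60% to 92%.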

Compound 3, largest response reached (reported as percent of maximum), in percent of the reference or control that the assay uses: 90%
Compound 3: the middle estimate sits 12 percentage points below what was measured; the measured number falls inside the stated range.
By their numbers in this assay, from the lowest: compound 2; then compounds 1 and 3 (each within the scatter of the next).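

In this assay, 2-(hydroxycarbamoyl)cyclopropyl at this aromatic carbon, para to a large group, gives a clear gain over 2-carbamoylethyl: a number 22 percentage points higher from compound 2 to compound 3 (beyond the scatter). Against carboxy the result is a number 4 percentage points higher from compound 1 to compound 3 (within the scatter), so the new group and carboxy cannot be told apart on maximal response, and replacing carboxy at this position does not always cost response, with compound 2 as the only case that loses it. No available evidence bears on the reason for the gain.

The exchange alters the chain, adds a three-membered ring, adds the hydroxy group on the amide nitrogen and defines two stereocentres, so the compounds shown do not assign the gain to any one of these. A 2-(hydroxycarbamoyl)ethyl group, a 2-carbamoylcyclopropyl group and the mirror-image cyclopropane would separate these contributions.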